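Trifluoromethoxy in place of methoxy in compound 2

The compounds below may be only part of what the source reports. "The series", "measured", "known", "first", "only" and "open" are said of these compounds alone.

Among the measured compounds shown here, in a functional assay on Jurkat cells (Homo sapiens) for antiproliferative activity, read by MTT assay, with a stated time of 72 h (a lower number here means a stronger inhibitor, a higher number a weaker inhibitor), compound 2 `COc1ccc(-c2ncnn2-c2cc(OC)c(OC)c(OC)c2)cc1` gives 50 nM, the lowest of the numbers measured so far. Compound 1 `COc1cc(-n2ncnc2-c2ccc(C)cc2)cc(OC)c1OC` gives 300 nM. For compound 3 `COc1cccc(-c2ncnn2-c2cc(OC)c(OC)c(OC)c2)c1` the reading is a limit of the assay, > 10000 nM.

Compound 4 `COc1cc(-n2ncnc2-c2ccc(OC(F)(F)F)cc2)cc(OC)c1OC` has trifluoromethyl in place of methyl on an oxygen on an aromatic ring, which reads as methoxy to trifluoromethoxy: trifluoromethyl in place of methyl on an oxygen on an aromatic ring.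

For the measured compounds named here, no measured step makes this exact change. The closest is a 6.0-fold lower number from compound 1 to compound 2 (0.78 log units; beyond the scatter), a modest step with methoxy in place of methyl on an aromatic carbon. The other two steps, an at least 33-fold higher number from compound 1 to compound 3 (1.52 log units; beyond the scatter) and an at least 200-fold higher number from compound 2 to compound 3 (2.30 log units; beyond the scatter), are large and show that the number can respond sharply to a change in this aryl group. They exchange the whole aryl group, so they serve only as a warning. A modest rise is expected, with a large loss not excluded: the expected step is a 3.6-fold higher number from compound 2 to compound 4 (0.56 log units; beyond the scatter). For compound 4 the estimate is 180 nM, with an expected range of 40 nM to 1500 nM.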

Compound 4, half-maximal inhibitory concentration: > 10000 nM
Compound 4: only a limit was reported (the forecaster's own chance of this, stated with the estimate: 8%); middle value at least 55-fold (1.74 log units) from the limit.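

Trifluoromethyl in place of methyl on an oxygen on an aromatic ring is a change this series does not tolerate: in this assay it gives an at least 200-fold higher number from compound 2 to compound 4 (2.30 log units; beyond the scatter), and the comparison with the methyl-bearing compound gives an at least 33-fold higher number from compound 1 to compound 4 (1.52 log units; beyond the scatter). Among the earlier compounds, a loss of this size appeared only on exchange of the whole aryl group for 3-methoxyphenyl, whereas here a change confined to the group on the oxygen is enough. The reading of compound 4 is a limit of the assay and not a number, so both steps are lower bounds only: the limit of > 10000 nM in this assay, at which 2 of the 4 values shown sit.

From the compounds shown here alone, how far the loss runs beyond that limit stays open. Also open, going by these compounds, is whether an ethoxy, difluoromethoxy or hydroxy group on the same aromatic carbon would hold the level of compound 2, 50 nM, or lose it as trifluoromethoxy does.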